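Removing the ethyl group from compound 2

The source may report more compounds than this note shows. Statements on the series, on what has been measured and on what is new or still open speak of the compounds shown alone.

In a functional assay on Jurkat cells (Homo sapiens) for inhibition, read by CCK-8 assay, with a stated time of 48 h (on this read-out higher numbers stand for weaker inhibition of growth and lower numbers for stronger inhibition of growth), compound 1 `Cc1ccccc1Nc1nc(Nc2ccccn2)ncc1Cl` gives 20100 nM. Compound 2 `CCN1CCN(c2ccc(Nc3ncc(Cl)c(Nc4ccccc4C)n3)nc2)CC1` is recorded only as a limit, > 100000 nM, so it has no exact number. Among the measured compounds shown here, the one measured step that bears on the next change is an at least 4.9-fold higher number from compound 1 to compound 2 (0.69 log units; beyond the scatter), brought by 4-ethylpiperazin-1-yl in place of hydrogen on an aromatic carbon. Compound 3 `Cc1ccccc1Nc1nc(Nc2ccc(N3CCNCC3)cn2)ncc1Cl` keeps the ring but has hydrogen in place of ethyl on an amine nitrogen in a ring. For the measured compounds named here, no measured step isolates this change, and the size of the step to compound 2 remains open at one end. A modest move toward stronger inhibition of growth in this assay is therefore expected, though compound 3 may also reach the limit. The expected step is an at least 2.5-fold lower number from compound 2 to compound 3 (0.39 log units; beyond the scatter). For compound 3 the estimated value is 40000 nM, with an expected range of 10000 nM to 100000 nM.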

Compound 3, concentration for 50% growth inhibition: 7870 nM
Beside the measured number, compound 3's estimate is 5.1-fold (0.71 log units) above it, and the stated range ends above it.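

In this assay, hydrogen in place of ethyl on the amine nitrogen in the ring gives an at least 12-fold lower number from compound 2 to compound 3 (1.10 log units; beyond the scatter), so the loss seen with 4-ethylpiperazin-1-yl does not belong to the ring as such. With piperazin-1-yl, the same place on the core moves the other way against the unsubstituted compound, with a 2.6-fold lower number from compound 1 to compound 3 (0.41 log units; beyond the scatter), a direction the earlier step did not show. The step from ethyl to hydrogen is open at one end, as compound 2 is recorded only as a limit: the limit of > 100000 nM in this assay, at which 1 of the 3 values shown sits.

The compounds shown leave open where a methyl or an acetyl group on that nitrogen would fall relative to ethyl and hydrogen. They also leave open whether a morpholin-4-yl group or a simple amine at the same place on the core would keep the stronger inhibition of growth.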